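The source may report more compounds than this note shows. Statements on the series, on what has been measured and on what is new or still open speak of the compounds shown alone.

Three amides built on one shared core are compared in an assay on HEK293 cells for displacement of a labelled ligand from metabotropic glutamate receptor 5 (Rattus norvegicus); on this read-out higher numbers stand for weaker inhibition and lower numbers for stronger inhibition. Compound 1 `O=C(Nc1cc(-c2ccccc2)nn1-c1ccccc1)c1cccc([N+](=O)[O-])c1` carries a 3-nitrophenyl on the carbonyl carbon, and in this assay compound 1 gives 2220 nM. Compound 2 `COc1cc(OC)cc(C(=O)Nc2cc(-c3ccccc3)nn2-c2ccccc2)c1` carries a 3,5-dimethoxyphenyl in that place. For compound 2 this assay reports only a limit, > 10000 nM. The step of an at least 4.5-fold higher number from compound 1 to compound 2 (0.65 log units; beyond the scatter) thus shows at least a modest weakening, and compound 2 stands at the limit of > 10000 nM in this assay, at which 1 of the 2 values shown sits, rather than at a measured number, so its true position could be anywhere past that point.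

Compound 3 `Cc1ccc(C(=O)Nc2cc(-c3ccccc3)nn2-c2ccccc2)cc1C` differs from compound 2 by 3,4-dimethylphenyl in place of 3,5-dimethoxyphenyl on a carbonyl carbon. Going by the values given here, the only measured step that bears on this change is an at least 4.5-fold higher number from compound 1 to compound 2 (0.65 log units; beyond the scatter), which shows that exchanging one aromatic ring on the carbonyl carbon for another can move the read-out well beyond the scatter, but it says nothing direct about a 3,4-dimethylphenyl. For compound 3 the number in this assay is expected to lie near the limit, with an estimate of 7000 nM and a range from 1500 nM to 30000 nM. The step of an at least 1.4-fold lower number from compound 2 to compound 3 (0.15 log units; that floor lies within the scatter) is expected to stay within the scatter, and a limit again is quite possible.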

Compound 3, inhibition constant: 430 nM
Estimate against measurement, compound 3: 16-fold (1.21 log units) above, outside the stated range (below it).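

At this place on the carbonyl carbon, the earlier compounds had shown only a loss, but in this assay the 3,4-dimethylphenyl brings a clear gain, with an at least 23-fold lower number from compound 2 to compound 3 (1.36 log units; beyond the scatter). Going by these compounds alone, the gain also holds against the only other measured number, with a 5.2-fold lower number from compound 1 to compound 3 (0.71 log units; beyond the scatter), so compound 3 is the strongest of the three and the aromatic ring at this place can move the read-out in either direction. The larger of these two steps is only a floor, and its true size remains unknown, since compound 2 has a limit rather than a measured number: the limit of > 10000 nM in this assay, at which 1 of the 3 values shown sits.

On these data alone, the three rings differ from one another in more than one substituent, so it remains open whether the gain needs both methyl groups of the 3,4-dimethylphenyl or just one of them. Also open, as far as these compounds go, is how this assay would read with an amine, a chlorine or a longer chain such as ethyl on the ring at this place, and whether changes elsewhere on the shared core would add to the gain seen with compound 3.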